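From Methyl to Isopropoxy on a Shared Core

This account rests on a few compounds, and the source may have more. Where it says the series, first, only, none or still open, it means among the compounds named here.

Of the compounds shown here, three with a shared core have been tested in a functional assay on MCF7 cells (Homo sapiens) for antiproliferative activity, read by sulforhodamine B assay, with a stated time of 72 h; a higher number here means a weaker inhibitor, a lower number a stronger inhibitor. Compound 1 `O=C(/C=C/c1csc2ccccc12)c1ccccc1O` gives 6600 nM. Compound 2 `O=C(/C=C/c1csc2ccccc12)c1cc(Br)ccc1O` carries a bromo group on an aromatic carbon and gives 1040 nM. Compound 3 `Cc1ccc(O)c(C(=O)/C=C/c2csc3ccccc23)c1` carries methyl on that same carbon and gives 7800 nM. Compound 3 thus stands level with compound 1 within the scatter, and its number is clearly higher than that of compound 2, as the measured comparison shows: a 7.5-fold higher number from compound 2 to compound 3 (0.88 log units; beyond the scatter).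

Compound 4 `CC(C)Oc1ccc(O)c(C(=O)/C=C/c2csc3ccccc23)c1` has isopropoxy in place of methyl on an aromatic carbon, para to a hydroxy group (isopropoxy in place of methyl on an aromatic carbon). Within the data shown here, two measured steps bear on this change. Methyl in place of hydrogen gave a 1.2-fold higher number from compound 1 to compound 3 (0.07 log units; within the scatter), which is within the scatter, while bromo in place of hydrogen gave a 6.3-fold lower number from compound 1 to compound 2 (0.80 log units; beyond the scatter), a modest gain. So this carbon can tolerate a change without any shift in the number, yet it can also give a real one. No oxygen-linked group has been measured here, so the guide is loose. A modest move towards a lower number is expected, a 2.6-fold lower number from compound 3 to compound 4 (0.41 log units; beyond the scatter). Compound 4 is estimated at 3000 nM, with an expected range from 900 nM to 10000 nM.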

Compound 4, half-maximal inhibitory concentration: 6600 nM
Compound 4: middle estimate off by 2.2-fold (0.34 log units), on the low side; the measured number falls inside the stated range.
By their numbers in this assay, from the lowest: compound 2; then compounds 1, 4 and 3 (each within the scatter of the next).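

Among these compounds, the first oxygen-linked group on this carbon, isopropoxy, does not move the number away from what methyl or hydrogen gave in this assay: the step from methyl is a 1.2-fold lower number from compound 3 to compound 4 (0.07 log units; within the scatter) and the step from hydrogen is no change at the digits printed from compound 1 to compound 4 (within the scatter). Set against bromo, the same group gives a 6.3-fold higher number from compound 2 to compound 4 (0.80 log units; beyond the scatter), so among the four groups now shown on this carbon, only bromo separates its compound from the rest, and compounds 1, 3 and 4 stay level within the scatter whether the group is hydrogen, methyl or isopropoxy. The data offer no explanation for why bromo stands apart from the other three groups.

The compounds shown leave open whether chloro or iodo on this carbon would behave like bromo or would join hydrogen, methyl and isopropoxy, and so whether the lower number belongs to bromo alone or extends to other halogens. They also leave open whether a very different group here, such as an amine, a carboxylic acid or a longer alkoxy chain, would shift the number at all.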